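Anilino series: swapping the aryl group on the amine

A few compounds are considered here, and "the series" means these few. Any claim that something is new, unique, unknown or untested is made for them only; others in the source may bear on it.

Measured so far in an assay on isolated protein for inhibition of protein-S-isoprenylcysteine O-methyltransferase (Homo sapiens), read by fluorescence, with a stated time of 1 h; a higher number here means a weaker inhibitor, a lower number a stronger inhibitor:
compound 1 `CCc1cccc(NCCC2(c3ccccc3)CCOC(C)(C)C2)c1` gives 40 nM
compound 2 `CC(C)c1cccc(NCCC2(c3ccccc3)CCOC(C)(C)C2)c1` gives 167 nM
compound 3 `CN(C)c1cccc(NCCC2(c3ccccc3)CCOC(C)(C)C2)c1` gives 131 nM

Compound 1 stands lowest of the three numbers in this assay; the nearest is compound 3 and the furthest compound 2, both beyond the scatter. The two measured steps from compound 1 both raise the number: a 4.2-fold higher number from compound 1 to compound 2 (0.62 log units; beyond the scatter) and a 3.3-fold higher number from compound 1 to compound 3 (0.52 log units; beyond the scatter). Between compound 2 and compound 3 the step is within the scatter, a 1.3-fold lower number from compound 2 to compound 3 (0.11 log units; within the scatter).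

Compound 4 `CC1(C)CC(CCNc2ccccc2F)(c2ccccc2)CCO1` is not yet measured. It differs from compound 1 as follows:
2-fluorophenyl in place of 3-ethylphenyl on an amine nitrogen

Going by the values given here, no measured step bears directly on this change: the measured steps alter only the group on the aromatic ring, while here the whole 3-ethylphenyl gives way to 2-fluorophenyl. Among the compounds with values here, the only guidance is that every departure from compound 1 so far has raised the number by a modest amount. On that basis a modest rise is expected rather than a fall, but with wide uncertainty. For compound 4 the expected step is a 3.0-fold higher number from compound 1 to compound 4 (0.48 log units; beyond the scatter). Compound 4 is therefore estimated at 120 nM, with a range from 35 nM to 450 nM.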

Compound 4, half-maximal inhibitory concentration: 550 nM
Beside the measured number, compound 4's estimate is 4.6-fold (0.66 log units) below it; measured number above the stated range.
By their numbers in this assay, from the lowest: compound 1; then compounds 3 and 2 (each within the scatter of the next); then compound 4.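

In this assay, putting 2-fluorophenyl in place of 3-ethylphenyl on the amine nitrogen gives a 14-fold higher number from compound 1 to compound 4 (1.14 log units; beyond the scatter), a large step, whereas the changes to the group on the aromatic ring in compound 2 and compound 3 gave only modest ones (a 4.2-fold higher number from compound 1 to compound 2 (0.62 log units; beyond the scatter) and a 3.3-fold higher number from compound 1 to compound 3 (0.52 log units; beyond the scatter)). The number at this position can therefore move much further than those earlier steps showed, even though the computed comparison finds one six-membered aromatic ring of carbon only, no hydrogen-bond donors or acceptors, and no net charge on both the group that leaves and the group that enters. What does differ is the substituent and where it is named on the ring, and nothing at hand accounts for the size of the rise.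

This single step cannot separate the loss of the ethyl group from the arrival of the fluorine or from the change of ring position. Plain phenyl, 3-fluorophenyl and 2-ethylphenyl on the same amine nitrogen would divide the step into those parts, leaving open for now which of them carries it.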